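Shifting the aryl substituent on a glucagon receptor antagonist series

The compounds below may be only part of what the source reports. "The series", "measured", "known", "first", "only" and "open" are said of these compounds alone.

Measured compounds:
compound 1, `CCCC(Oc1cnn(-c2cccc(Cl)c2)c1)c1ccc(C(=O)NCCC(=O)O)cc1`, 16900 nM in a functional assay on cells for antagonist activity at Glucagon receptor (Homo sapiens), read by cAMP accumulation; a higher number here means a weaker inhibitor, a lower number a stronger inhibitor
compound 2, `CCCC(Oc1cnn(-c2cccc(CC)c2)c1)c1ccc(C(=O)NCCC(=O)O)cc1`, 4530 nM in this assay

Among the compounds with values here, compound 2 stands at the lowest of the two numbers so far; its nearest neighbour is compound 1, and the gap between them is a 3.7-fold lower number from compound 1 to compound 2 (0.57 log units; beyond the scatter). That step, ethyl in place of chloro on an aromatic carbon, is the only measured one in the set.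

Compound 3, `CCCC(Oc1cnn(-c2ccccc2C)c1)c1ccc(C(=O)NCCC(=O)O)cc1`, is not yet measured. It differs from compound 2 by 2-methylphenyl in place of 3-ethylphenyl on an aromatic nitrogen. The step from compound 1 to compound 2 does not bear directly on this change: it swapped one group for another at the same ring position, whereas here the group moves to a different ring position and shrinks from ethyl to methyl. Within the data shown here, with no measured step that tests a change of position, the expected size of the step is uncertain. Compound 3 is estimated at 9000 nM, within 3000 nM to 27000 nM, which would mean an expected step of a 2.0-fold higher number from compound 2 to compound 3 (0.30 log units; within the scatter) from compound 2, a modest weakening that may well fall within the scatter.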

Compound 3, antagonist equilibrium constant: > 23600 nM
Compound 3 ended at the assay's limit; the forecaster's own chance of this, stated with the estimate: 10%; middle value at least 2.6-fold (0.41 log units) away from the limit.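

The reading for compound 3 is a limit of the assay and not a number: the limit of > 23600 nM in this assay, at which 1 of the 3 values shown sits.

Replacing 3-ethylphenyl with 2-methylphenyl on the aromatic nitrogen gives an at least 5.2-fold higher number from compound 2 to compound 3 (0.71 log units; beyond the scatter), so the gain seen with the ethyl group does not carry over to this change, the first shown here that alters where the alkyl group sits on the phenyl ring. The comparison with the 3-chlorophenyl group is less decisive, since it gives an at least 1.3-fold higher number from compound 1 to compound 3 (0.14 log units; that floor lies within the scatter), and that floor does not set the two compounds apart.

Compound 3 changes the position of the group and shortens it from ethyl to methyl in a single step, so the compounds shown cannot say which of the two changes accounts for the higher number in this assay. Going by these compounds, a 3-methylphenyl or a 2-ethylphenyl group would separate these two changes, while how far the number rises for compound 3 remains unknown, as does the outcome of placing an amine on the phenyl ring.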